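Swapping methyl for chloro on the phenyl arm of imidazole ethers

This account rests on a few compounds, and the source may have more. Where it says the series, first, only, none or still open, it means among the compounds named here.

Measured compounds:
Compound 1, `Clc1ccc(OC(CCn2ccnc2)c2ccccc2)cc1`, gives 84900 nM.
Compound 2, `Cc1ccc(OC(CCn2ccnc2)c2ccccc2)cc1`, gives 141000 nM.
Compound 3, `Cc1ccc(C(CCn2ccnc2)Oc2ccc(Cl)cc2Cl)cc1`, gives 40000 nM.

These three were tested in a functional assay on U-937 cells (Homo sapiens) for cytotoxicity; on this read-out lower numbers stand for higher toxicity in this test and higher numbers for lower toxicity in this test. Compound 3 stands lowest of the three numbers, and both its distances, to compound 1 and to compound 2, are beyond the usual scatter. The core of compound 3 and the core of compound 2 differ, but that difference is not broken down here.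

One structural change appears twice among these compounds: chloro in place of methyl on an aromatic carbon. Its effect is known on one pair, where it gave a 1.7-fold lower number from compound 2 to compound 1 (0.22 log units; within the scatter). The unmeasured compound 4, `Clc1ccc(C(CCn2ccnc2)Oc2ccc(Cl)cc2Cl)cc1`, arises from compound 3 by the same change, (chloro in place of methyl on an aromatic carbon), at the same kind of place: para to a large group on a six-membered aromatic ring of carbon only.

Because the step from compound 2 to compound 1 was a 1.7-fold lower number from compound 2 to compound 1 (0.22 log units; within the scatter), a step of similar size is expected here, a 1.6-fold lower number from compound 3 to compound 4 (0.20 log units; within the scatter). Compound 4 is therefore estimated at 25000 nM, with the range 12000 nM to 55000 nM.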

Compound 4, half-maximal cytotoxic concentration: 61000 nM
For compound 4 the middle estimate is 2.4-fold (0.39 log units) below the measured one; measured number outside the range, above it.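

In this assay, chloro in place of methyl on the second core gave a 1.5-fold higher number from compound 3 to compound 4 (0.18 log units; within the scatter), so on this core too the swap left the number within the usual scatter of repeated measurements. Set beside the first core, the two steps cannot be told apart, and the swap shows no measurable dependence on the core in this pair of examples: the same change on two cores in this assay, a 1.7-fold lower number (0.22 log units; within the scatter) from compound 2 to compound 1 and a 1.5-fold higher number (0.18 log units; within the scatter) from compound 3 to compound 4, 2.5-fold (0.40 log units) apart, within the scatter of two such steps. This does not show that the change has a fixed effect or a real direction, since the two printed directions differ and both steps are small enough to be scatter, and two pairs say nothing firm about any further core.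

Still open, from the compounds shown here alone, is whether another group in the same place, such as bromo, methoxy or trifluoromethyl, would move the number beyond the scatter. Also open, going by these compounds, is what a longer chain in the shared core would do, and whether a third core would behave like these two.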